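The source may hold more compounds than are shown below. What is called first, only, known or untested is meant among the compounds shown, and "the series" means these compounds.

Measured so far in an ADME assay on NIH3T3 cells (Mus musculus) for cytotoxicity, read by MTT assay; a higher number here means a weaker inhibitor, a lower number a stronger inhibitor:
- compound 1 `N#Cc1c(-c2ccc(Cl)cc2)c(C#N)c(=O)n(/N=C/c2cn(-c3ccccc3)nc2-c2ccccc2)c1N`: 64 ug/mL
- compound 2 `COc1cc(-c2c(C#N)c(N)n(/N=C/c3cn(-c4ccccc4)nc3-c3ccccc3)c(=O)c2C#N)cc(OC)c1OC`: 64 ug/mL
- compound 3 `N#Cc1c(-c2ccccc2C(F)(F)F)c(C#N)c(=O)n(/N=C/c2cn(-c3ccccc3)nc2-c2ccccc2)c1N`: 56 ug/mL

Compound 1 stands level with compound 2 at the digits given, the two of them the highest of the three numbers; compound 3 is the furthest from it, and that gap, a 1.1-fold lower number from compound 1 to compound 3 (0.06 log units; within the scatter), lies within the scatter, as does no change at the digits printed from compound 1 to compound 2 (within the scatter).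

Compound 4 `N#Cc1c(-c2ccc(C(F)(F)F)cc2)c(C#N)c(=O)n(/N=C/c2cn(-c3ccccc3)nc2-c2ccccc2)c1N` differs from compound 1 by trifluoromethyl in place of chloro on an aromatic carbon. Among the measured compounds shown here, the steps that bear on this change are those at the same aromatic carbon: no change at the digits printed from compound 1 to compound 2 (within the scatter) and a 1.1-fold lower number from compound 1 to compound 3 (0.06 log units; within the scatter), both flat, and a 1.1-fold lower number from compound 2 to compound 3 (0.06 log units; within the scatter) likewise. Three different groups at that position leave this assay unmoved, so no step beyond the scatter is expected for compound 4 either.

Compound 4 is therefore expected to give about 60 ug/mL, between 38 ug/mL and 95 ug/mL, a step of a 1.1-fold lower number from compound 1 to compound 4 (0.03 log units; within the scatter) that is estimated to stay within the scatter.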

Compound 4, half-maximal inhibitory concentration: > 200 ug/mL
Compound 4: a limit, no number (the forecaster's own chance of this, stated with the estimate: 10%); middle value at least 3.3-fold (0.52 log units) away from the limit.
By their numbers in this assay, from the lowest: compounds 3, 1 and 2 (each within the scatter of the next). At a limit, above all of these: compound 4.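

In this assay the value of compound 4 is a limit of the assay and not a number: the limit of > 200 ug/mL in this assay, at which 1 of the 4 values shown sits.

This aromatic carbon, flat across compounds 1, 2 and 3, does respond to the group it carries, with an at least 3.1-fold higher number from compound 1 to compound 4 (0.49 log units; beyond the scatter) for trifluoromethyl in place of chloro and an at least 3.1-fold higher number from compound 2 to compound 4 (0.49 log units; beyond the scatter) against the 3,4,5-trimethoxyphenyl group. The placing of the trifluoromethyl group also counts, with an at least 3.5-fold higher number from compound 3 to compound 4 (0.55 log units; beyond the scatter).

Going by these compounds, the true size of these steps stays open. So does whether a 4-methoxyphenyl or 4-aminophenyl group at this carbon would follow compound 4 or compound 1.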